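Chloro to nitro on the aryl ring of a thiosemicarbazone

The source may hold more compounds than are shown below. What is called first, only, known or untested is meant among the compounds shown, and "the series" means these compounds.

Measured compounds:
- compound 1, `CC1=CC[C@H](C(C)(C)NC(=S)N/N=C/c2ccccc2Cl)CC1`, > 100000 nM
- compound 2, `CC1=CC[C@H](C(C)(C)NC(=S)N/N=C/c2cccc(Cl)c2)CC1`, 26900 nM
- compound 3, `CC1=CC[C@H](C(C)(C)NC(=S)N/N=C/c2ccccc2[N+](=O)[O-])CC1`, > 100000 nM

All three share one core and differ only in the group on the carbon with a double bond to nitrogen. They were tested in a functional assay on 786-0 cells (Homo sapiens) for inhibition, read by sulforhodamine B assay, with a stated time of 48 h; on this read-out higher numbers stand for weaker inhibition of growth and lower numbers for stronger inhibition of growth. Compound 1 gives > 100000 nM, which is a limit of the assay and not a number. Compound 3 gives > 100000 nM, likewise a limit. Among the measured compounds shown here, compound 2 is the only one with a number, 26900 nM.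

Compound 2 differs from compound 1 by 3-chlorophenyl in place of 2-chlorophenyl on a carbon with a double bond to nitrogen; the two have the same atoms joined differently. That change gives an at least 3.7-fold lower number from compound 1 to compound 2 (0.57 log units; beyond the scatter). Compound 3 differs from compound 1 by nitro in place of chloro on an aromatic carbon. Because both values sit at the limit of > 100000 nM in this assay, at which 2 of the 3 values shown sit, this gives a step that the two limits leave unreadable from compound 1 to compound 3.

Compound 4, `CC1=CC[C@H](C(C)(C)NC(=S)N/N=C/c2cccc([N+](=O)[O-])c2)CC1`, is not yet measured. It differs from compound 2 by nitro in place of chloro on an aromatic carbon. This is the same kind of change as from compound 1 to compound 3, but not the same: there the nitro enters ortho to a large group, here it enters meta to a large group. For the measured compounds named here, the one measured example of this kind of change cannot be read, so the expectation rests only on compound 2 being the one compound with a number, 26900 nM. The expected step is a 2.2-fold higher number from compound 2 to compound 4 (0.35 log units; beyond the scatter), with a real chance that only a limit is returned. Compound 4 is thus estimated at 60000 nM, between 20000 nM and 100000 nM.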

Compound 4, concentration for total growth inhibition: > 100000 nM
Compound 4: a limit, no number; the forecaster's own chance of this, stated with the estimate: 45%; at least 1.6-fold (0.22 log units) between middle value and limit.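

In this assay, putting nitro in place of chloro on the compound with the 3-chlorophenyl group gives an at least 3.7-fold higher number from compound 2 to compound 4 (0.57 log units; beyond the scatter), so at this place, meta to a large group, the chloro compound keeps a measurable number and the nitro compound does not. Going by these compounds, compound 4 gives > 100000 nM, which is a limit of the assay and not a number, so the step shows only a direction and a minimum size, and its true size stays unknown. The same change on compound 1 cannot be read, which leaves one readable example and no real test of whether the change carries from one core to another, since a second example would need a number at both ends: the limit of > 100000 nM in this assay, at which 3 of the 4 values shown sit.

Among the compounds shown here, compound 2 remains the only compound here with a number, 26900 nM, so it is open whether that number depends on chloro in particular or whether another group at the same place, such as fluoro, methoxy, an amine or a carboxylic acid, would also give a number. On these data alone, it is equally open whether any such group would instead fall to the same limit as the nitro compound.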